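Dropping a pyrazole methyl from compound 1

This account rests on a few compounds, and the source may have more. Where it says the series, first, only, none or still open, it means among the compounds named here.

Among the measured compounds shown here, compound 1 `Cc1nn(Cc2ccccc2)c(C)c1-c1ccc(N2CCc3cccc(C(=O)Nc4nc5ccccc5s4)c3C2)nc1C(=O)O` is one of two compounds measured in an ADME assay on isolated protein for binding affinity to Apoptosis regulator Bcl-2 (Homo sapiens), read by TR-FRET, with a stated time of 1 h; a lower number here means a stronger inhibitor, a higher number a weaker inhibitor; compound 1 gives 548 nM, the higher of the two numbers. For the measured compounds named here, the only other measured compound, compound 2 `Cc1c(-c2ccc(N3CCc4cccc(C(=O)Nc5nc6ccccc6s5)c4C3)nc2C(=O)O)cnn1CC1CCCCC1`, gives 28.5 nM in this assay, a gap beyond the usual scatter, though the two structures differ in more than one place. Compound 3 `Cc1nn(Cc2ccccc2)cc1-c1ccc(N2CCc3cccc(C(=O)Nc4nc5ccccc5s4)c3C2)nc1C(=O)O` is not yet measured; it differs from compound 1 by hydrogen in place of methyl on an aromatic carbon. Going by the values given here, with no single-point step available, a step from compound 1 to compound 3 of a 1.1-fold lower number from compound 1 to compound 3 (0.04 log units; within the scatter) is expected, likely within the scatter. Compound 3 is estimated at 500 nM, between 200 nM and 1500 nM.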

Compound 3, inhibition constant: 413 nM
Compound 3: the middle estimate sits 1.2-fold (0.08 log units) above what was measured; low and high end bracket the measured number.
By their numbers in this assay, from the lowest: compound 2; then compounds 3 and 1 (each within the scatter of the next).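

In this assay, hydrogen in place of methyl on this aromatic carbon, next to the ring atom that bears a benzyl group, gives a 1.3-fold lower number from compound 1 to compound 3 (0.12 log units; within the scatter). Among the compounds shown here, this is the first comparison here that differs in one place, and it shows that with the benzyl group present, this methyl can be exchanged for hydrogen without a change beyond the scatter. No available evidence offers an explanation for this result.

As far as these compounds go, it remains open how an ethyl or methoxy group on this carbon would read. Also open, from the compounds shown here alone, is whether the remaining methyl, two ring bonds away, could likewise give way to hydrogen.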